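This account rests on a few compounds, and the source may have more. Where it says the series, first, only, none or still open, it means among the compounds named here.

Measured so far in a functional assay on KOPN-8 cells (Homo sapiens) for antiproliferative activity, with a stated time of 72 h; a lower number here means that less compound is needed, a higher number that more compound is needed for the effect:

Compound 1 `COc1ccc(-c2cc(=O)c3c(OC)cc(OC)cc3[nH]2)cc1` gives > 31100 nM, which is a limit of the assay.
Compound 2 `COc1ccc(-c2cc(=O)c3c(OC)cc(OC)cc3n2Cc2ccccc2)cc1` gives > 17300 nM, which is a limit of the assay.
Compound 3 `COc1ccc(-c2cc(=O)c3c(OC)cc(OC)cc3n2S(=O)(=O)c2ccc(Cl)cc2)cc1` gives > 34400 nM, which is a limit of the assay.

Compound 3 therefore stands nowhere definite on the numbers shown: its value is a limit, and the two other values are limits as well (the limit of > 17300 nM in this assay, at which 1 of the 3 values shown sits, (the limit of > 31100 nM in this assay, at which 1 of the 3 values shown sits), (the limit of > 34400 nM in this assay, at which 1 of the 3 values shown sits)), so no ordering among the three can be read. The steps on the aromatic nitrogen of the shared core, a step that the two limits leave unreadable from compound 1 to compound 2, a step that the two limits leave unreadable from compound 1 to compound 3 and a step that the two limits leave unreadable from compound 2 to compound 3, are all unreadable for the same reason.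

Compound 4 `COc1ccc(-c2cc(=O)c3c(OC)cc(OC)cc3n2S(=O)(=O)c2ccc(C)cc2)cc1` differs from compound 3 by methyl in place of chloro on an aromatic carbon. Among the compounds with values here, no measured step touches the sulfonyl aryl ring, and the steps that exist give no size at all. Within the data shown here, there is thus no evidence for a step in this assay in either direction beyond the usual scatter, and the most likely outcome is again a limit.

Compound 4 is expected to give about 40000 nM in this assay, within a range from 15000 nM to 100000 nM.

The step that the limit leaves unreadable from compound 3 to compound 4 that this estimate implies is expected to be effectively none.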

Compound 4, half-maximal effective concentration: > 44800 nM
Compound 4: no number, only a limit (the forecaster's own chance of this, stated with the estimate: 85%); middle value at least 1.1-fold (0.04 log units) away from the limit.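

Compound 4 gives > 44800 nM, which is a limit. Compound 1, compound 2 and compound 3 also stand at limits, so none of the steps to compound 4 can be read. The compounds shown leave open whether any group on the aromatic nitrogen of the shared core gives a readable value in this assay, and how these groups rank.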